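The compounds below may be only part of what the source reports. "The series", "measured", "known", "first", "only" and "open" are said of these compounds alone.

Measured compounds in the series:

compound 1 `COc1ccc(Nc2nc(Oc3cccc(NC(=O)C=C(C)C)c3)c3sccc3n2)cc1` — 46100 nM
compound 2 `COc1ccc(Nc2nc(Oc3cccc(NC(=O)/C=C/C(C)C)c3)c3sccc3n2)cc1` — > 50000 nM

In a functional assay on MCF7 cells (Homo sapiens) for inhibition, read by MTT assay, with a stated time of 72 h (on this read-out higher numbers stand for weaker inhibition and lower numbers for stronger inhibition), compound 1 gives 46100 nM, the only plain number shown for the series. Compound 2 gives > 50000 nM, which is a limit of the assay and not a number. The step of an at least 1.0-fold higher number from compound 1 to compound 2 (0.03 log units; that floor lies within the scatter) cannot be sized further because the limit of > 50000 nM in this assay, at which 1 of the 2 values shown sits, sets its floor; what is shown is that the floor lies within the scatter, so the acyl change did not move the read-out discernibly.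

Compound 3 `COc1ccc(Nc2nc(Oc3cccc(NC(=O)C=C(C)C)c3)c3sccc3n2)cn1` is the next case. Its change from compound 1 is 6-methoxypyridin-3-yl in place of 4-methoxyphenyl on a nitrogen on an aromatic ring, so the alteration sits on the anilino side of the shared core, not on the acyl group. Going by the values given here, the one measured step concerns the acyl group only and does not bear on this position. There is therefore no basis for expecting a shift in either direction beyond the scatter, and the step of a 1.0-fold lower number from compound 1 to compound 3 (0.00 log units; within the scatter) is estimated as essentially flat. Compound 3 is expected to give 46000 nM in this assay, within a range of 18000 nM to 120000 nM, with a real chance that only a limit is reported.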

Compound 3, half-maximal inhibitory concentration: > 100000 nM
Compound 3 was reported as a limit; the forecaster's own chance of this, stated with the estimate: 45%; at least 2.1-fold (0.33 log units) between middle value and limit.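

Going by these compounds alone, this is the first reading at the position on a nitrogen on an aromatic ring, and in this assay the change to 6-methoxypyridin-3-yl from 4-methoxyphenyl gives an at least 2.1-fold higher number from compound 1 to compound 3 (0.33 log units; beyond the scatter), while the one earlier step, on the acyl group, had a floor that lay within the scatter. Compound 3 gives > 100000 nM, which is a limit of the assay and not a number. The step therefore shows a direction and a floor, not a full size, and that floor is set because of this limit: the limit of > 100000 nM in this assay, at which 1 of the 3 values shown sits.

With compound 1 at 46100 nM as the only plain number, the compounds shown include no change that lowers the number, so it stays open whether any group on this nitrogen can do so. As far as these compounds go, it also stays open whether the step follows the ring nitrogen of 6-methoxypyridin-3-yl alone, and how a morpholine or a carboxylic acid in place of the methoxy group would read.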